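Aryl amine variation on the shared core: inhibition unchanged so far

The source may report more compounds than this note shows. Statements on the series, on what has been measured and on what is new or still open speak of the compounds shown alone.

Measured compounds:
Compound 1, `Cc1ccc(C)c(Nc2c(-c3ccc4[nH]nc(C)c4c3)nc3cnc(N4CCN(C)CC4)cn23)c1`, gives 0% in a functional assay on MV4-11 cells (Homo sapiens) for inhibition, with a stated time of 120 h, tested at 10 uM; on this read-out higher numbers stand for more inhibition at the one concentration tested (going by the name of the read-out) and lower numbers for less inhibition.
Compound 2, `Cc1n[nH]c2ccc(-c3nc4cnc(N5CCN(C)CC5)cn4c3Nc3ccc(Cl)cc3F)cc12`, gives 0% in this assay.

Compound 2 stands level with compound 1 on the numbers shown: the step of no change at the digits printed from compound 1 to compound 2 (within the scatter) lies within the scatter. Exchange of the aryl group on the nitrogen on the aromatic ring has so far left inhibition flat.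

Compound 3, `Cc1cc(Br)ccc1Nc1c(-c2ccc3[nH]nc(C)c3c2)nc2cnc(N3CCN(C)CC3)cn12`, is not yet measured. It differs from compound 2 by 4-bromo-2-methylphenyl in place of 4-chloro-2-fluorophenyl on a nitrogen on an aromatic ring. Among the compounds with values here, the only step that bears on it is the one from compound 1 to compound 2, which exchanged a substituted phenyl at the same place and was flat. Compound 3 is therefore expected to show no step beyond the scatter, with a number 2 percentage points higher from compound 2 to compound 3 (within the scatter) estimated near zero. Compound 3 is expected to give 2%, estimated between -8% and 15%.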

Compound 3, a percentage reported as inhibition, at one concentration (the size of the read-out at that concentration, not a potency): 59.4%
Estimate against measurement, compound 3: 57.4 percentage points below, and the stated range ends below it.
By their numbers in this assay, from the lowest: compounds 1 and 2 (each within the scatter of the next); then compound 3.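

In this assay, the group on a nitrogen on an aromatic ring turns out not to be a silent place on the shared core: 4-bromo-2-methylphenyl in place of 4-chloro-2-fluorophenyl gives a number 59.4 percentage points higher from compound 2 to compound 3 (beyond the scatter), and in place of 2,5-dimethylphenyl it gives a number 59.4 percentage points higher from compound 1 to compound 3 (beyond the scatter). The flat step between compound 1 and compound 2 therefore holds for that pair only and does not extend to all substituted phenyl groups here. Nothing at hand accounts for the gain or assigns it to the bromine or to the methyl.

Going by these compounds, compound 3 differs from compound 2 in both substituents on the phenyl ring, so the contribution of each exchange stays open; 4-chloro-2-methylphenyl and 4-bromo-2-fluorophenyl would separate them. Also open, on these data alone, is whether the inhibition depends on an aromatic ring at this place at all, as a cyclohexyl group there would show, and what potency lies behind a read-out taken at one concentration.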